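Replacing the Aromatic Group on a Weak Antiproliferative Core

The source may hold more compounds than are shown below. What is called first, only, known or untested is meant among the compounds shown, and "the series" means these compounds.

Compound 1 `N#CC1=C(N)Oc2c(c3nc4ccccc4nc3c3ccccc23)C12C(=O)N(Cc1cnnn1-c1cccc(Cl)c1)c1ccccc12` and compound 2 `CC(=O)Nc1ccc(-n2nncc2CN2C(=O)C3(C(C#N)=C(N)Oc4c(N)cc5nc6ccccc6nc5c43)c3ccccc32)cc1` share one core and were both tested in a functional assay on A549 cells (Homo sapiens) for antiproliferative activity, read by MTT assay, with a stated time of 48 h; a higher number here means a weaker inhibitor, a lower number a stronger inhibitor. Compound 1 gives 32600 nM in this assay. For compound 2 the reading in this assay is > 50000 nM, which is a limit of the assay and not a number. Going by the values given here, compound 2 therefore stands at the limit of > 50000 nM in this assay, at which 1 of the 2 values shown sits, so no sized step between compound 1 and compound 2 can be drawn.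

Compound 3 `N#CC1=C(N)Oc2c(N)cc3nc4ccccc4nc3c2C12C(=O)N(Cc1cnnn1-c1ccc([N+](=O)[O-])cc1[N+](=O)[O-])c1ccccc12` has not yet been measured. It differs from compound 2 in one place: 2,4-dinitrophenyl in place of 4-acetamidophenyl on an aromatic nitrogen. Among the compounds with values here, no measured pair shows the effect of such a change on this core, so the expectation is a step no larger than the usual scatter, in no set direction. In this assay compound 3 is expected to give about 45000 nM, within a likely range from 15000 nM to 120000 nM. The expected step of an at least 1.1-fold lower number from compound 2 to compound 3 (0.04 log units; that floor lies within the scatter) is accordingly small, and a reading that is again only a limit would not be surprising.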

Compound 3, half-maximal inhibitory concentration: > 50000 nM
Compound 3: only a limit was reported (the forecaster's own chance of this, stated with the estimate: 50%); middle value at least 1.1-fold (0.04 log units) from the limit.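

Going by these compounds alone, compound 2 and compound 3 each gave only a limit in this assay, not a number, so no step between them can be read: the limit of > 50000 nM in this assay, at which 2 of the 3 values shown sit. The compounds shown leave open whether 2,4-dinitrophenyl or 4-acetamidophenyl gives the stronger inhibitor on the shared core.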